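The source may hold more compounds than are shown below. What is called first, only, known or untested is meant among the compounds shown, and "the series" means these compounds.

Compound 1 `Brc1ccc2[nH]cc(C(c3ccccc3)c3c[nH]c4ccc(Br)cc34)c2c1`: 900 nM
Compound 2 `COc1ccc(C(c2c[nH]c3ccc(Br)cc23)c2c[nH]c3ccc(Br)cc23)cc1OC`: 6100 nM

Within the data shown here, in a functional assay on HeLa cells (Homo sapiens) for inhibition, read by MTT assay, with a stated time of 48 h (on this read-out higher numbers stand for weaker inhibition and lower numbers for stronger inhibition), compound 2 gives 6100 nM, the higher of the two numbers so far, which makes it the weaker inhibitor of the pair. Compound 3 `COc1ccc(OC)c(C(c2c[nH]c3ccc(Br)cc23)c2c[nH]c3ccc(Br)cc23)c1` keeps the shared core and changes one group: 2,5-dimethoxyphenyl in place of 3,4-dimethoxyphenyl on a saturated chain carbon bound to two aromatic carbons. In words, 2,5-dimethoxyphenyl comes in place of 3,4-dimethoxyphenyl on a saturated chain carbon bound to two aromatic carbons. Among the measured compounds shown here, only one measured step bears on this: a 6.8-fold higher number from compound 1 to compound 2 (0.83 log units; beyond the scatter), which came with putting 3,4-dimethoxyphenyl in place of phenyl. For the measured compounds named here, that step was modest, and no measured pair yet compares two dimethoxyphenyl groups, so the guidance is thin. Since the swap only rejoins the same atoms, a smaller change is expected, with no clear direction. The expected step is a 1.4-fold lower number from compound 2 to compound 3 (0.13 log units; within the scatter). For compound 3 the estimated value is 4500 nM, with an expected range from 1500 nM to 13000 nM.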

Compound 3, half-maximal inhibitory concentration: 5100 nM
Beside the measured number, compound 3's estimate is 1.1-fold (0.05 log units) below it, within the range that was stated.
By their numbers in this assay, from the lowest: compound 1; then compounds 3 and 2 (each within the scatter of the next).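

In this assay, putting 2,5-dimethoxyphenyl in place of 3,4-dimethoxyphenyl on this saturated chain carbon gives a 1.2-fold lower number from compound 2 to compound 3 (0.08 log units; within the scatter), so these two ways of placing the methoxy groups on the ring cannot be told apart here. Set against plain phenyl, the new group gives a 5.7-fold higher number from compound 1 to compound 3 (0.75 log units; beyond the scatter), so the weaker inhibition first seen with 3,4-dimethoxyphenyl also appears with a second dimethoxyphenyl group and is not confined to that one arrangement. Why the two methoxy groups go with weaker inhibition is not explained by any measurement available here.

The compounds shown leave open whether a phenyl with a single methoxy group would read like compound 1 or like compounds 2 and 3. They also leave open how a phenyl carrying a hydroxyl or an amine would behave at this position.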